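A few compounds are considered here, and "the series" means these few. Any claim that something is new, unique, unknown or untested is made for them only; others in the source may bear on it.

Measured compounds:
compound 1, `C[C@@H]1CN(c2sc(CO)nc2-c2nc3ccccc3[nH]2)CCN1C(=O)Cn1cnc2cccnc21`, gives 3380 nM in an assay on blood for inhibition of C-X-C chemokine receptor type 3 (Homo sapiens), with a stated time of 30 min; on this read-out lower numbers stand for stronger inhibition and higher numbers for weaker inhibition
compound 2, `CCOc1ncc(-c2nc(C(F)(F)F)sc2N2CCN(C(=O)Cn3cnc4ccccc43)[C@H](C)C2)cn1`, gives 192 nM in this assay

Compound 2 holds the lower of the two numbers, and the gap to compound 1 lies beyond the scatter. Compound 3, `CCOc1ncc(-c2nc(C(F)(F)F)sc2N2CCN(C(=O)Cn3ncc4cccnc43)[C@H](C)C2)cn1`, differs from compound 2 by a group of 9 heavy atoms (6 carbon, 3 nitrogen; one five-membered aromatic ring with 2 hetero atoms, one six-membered aromatic ring with 1 hetero atom) in place of a group of 9 heavy atoms (7 carbon, 2 nitrogen; one five-membered aromatic ring with 2 hetero atoms, one six-membered aromatic ring of carbon only), on a saturated chain carbon bound to a carbonyl carbon. For the measured compounds named here, no measured pair shows this change alone, so its effect is open; the expected step is a 1.7-fold higher number from compound 2 to compound 3 (0.22 log units; within the scatter), a small weakening that may not exceed the scatter. In this assay compound 3 is expected to give 320 nM, within 100 nM to 1000 nM.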

Compound 3, half-maximal inhibitory concentration: 372 nM
The estimate for compound 3 lay 1.2-fold (0.07 log units) below the measured number; the range from low to high includes it.
By their numbers in this assay, from the lowest: compounds 2 and 3 (each within the scatter of the next); then compound 1.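

Compounds 2 and 3 form the first pair differing in one place, and on the saturated chain carbon bound to a carbonyl carbon, replacing 1H-benzimidazol-1-yl with the group of 6 carbon and 3 nitrogen atoms gives a 1.9-fold higher number from compound 2 to compound 3 (0.29 log units; within the scatter) in this assay. This place therefore accepts both bicyclic groups without a change that can be told from the scatter. No measurement bears on why the two groups read alike. Still open, going by these compounds, is how a single ring at this place, such as phenyl or imidazole, would read, and whether an amine or a methoxy group on the bicyclic group would shift the number.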